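The source may hold more compounds than are shown below. What is called first, only, known or untested is meant among the compounds shown, and "the series" means these compounds.

Measured so far:
- compound 1 `CCS[C@@H]1[C@H](SCC)[C@@H](Cn2cc(-c3ccccc3)nn2)O[C@H]1n1ccc(=O)[nH]c1=O`: 8380 nM
- compound 2 `CCS[C@@H]1[C@H](SCC)[C@@H](Cn2cc(-c3ccccc3C(F)(F)F)nn2)O[C@H]1n1ccc(=O)[nH]c1=O`: 30300 nM

In a functional assay on HepG2 cells (Homo sapiens) for cytotoxicity, read by MTT assay, with a stated time of 72 h (a lower number here means that less compound is needed, a higher number that more compound is needed for the effect), compound 1 gives 8380 nM and holds the lowest of the two numbers; its nearest neighbour is compound 2 at 30300 nM, which carries a trifluoromethyl on the phenyl. Within the data shown here, the one step measured on this pair, a 3.6-fold higher number from compound 1 to compound 2 (0.56 log units; beyond the scatter), shows that even a small addition on the phenyl moves the number beyond the scatter.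

Compound 3 `CCOC(=O)c1cn(C[C@H]2O[C@@H](n3ccc(=O)[nH]c3=O)[C@H](SCC)[C@@H]2SCC)nn1` is not yet measured. Relative to compound 1 it carries ethoxycarbonyl in place of phenyl on an aromatic carbon. Among the measured compounds shown here, no measured step covers the exchange of the phenyl for a group without a ring, so the step from compound 1 to compound 2 is the only guide, and it concerns a change on the phenyl rather than its removal. It indicates that this position is sensitive, so a change beyond the scatter is plausible, with the direction open.

On that basis compound 3 is expected to give 12000 nM, within a range from 4000 nM to 40000 nM, the estimated step from compound 1 being a 1.4-fold higher number from compound 1 to compound 3 (0.16 log units; within the scatter).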

Compound 3, half-maximal effective concentration: >= 100000 nM
Compound 3 was reported as a limit; the forecaster's own chance of this, stated with the estimate: 15%; at least 8.3-fold (0.92 log units) between middle value and limit.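

Compound 3 is reported only as a limit of the assay, not as a number, in this assay: the limit of >= 100000 nM in this assay, at which 1 of the 3 values shown sits.

Even so, the exchange of the phenyl for ethoxycarbonyl on this aromatic carbon gives an at least 11-fold higher number from compound 1 to compound 3 (1.07 log units; beyond the scatter), and the exchange of the 2-(trifluoromethyl)phenyl for the same group gives an at least 3.3-fold higher number from compound 2 to compound 3 (0.51 log units; beyond the scatter). The earlier pair showed only that a substituent on the phenyl shifts the number, with a 3.6-fold higher number from compound 1 to compound 2 (0.56 log units; beyond the scatter), whereas these steps show that replacing the whole aromatic group with a ring-free ester moves the number further, and that both compounds with a phenyl ring in this place stay on the measurable side of the limit.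

On these data alone, because this change removes the ring and brings in the ester together, the three compounds cannot show which of the two matters, and since compound 3 is a limit, the full size of the step stays unknown. A cyclohexyl group, a pyridyl ring, a plain alkyl chain or a carboxylic acid at this carbon would bear on that question, as would a phenyl with a methoxy group in place of the trifluoromethyl.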